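A few compounds are considered here, and "the series" means these few. Any claim that something is new, unique, unknown or untested is made for them only; others in the source may bear on it.

In a functional assay on MIA PaCa-2 cells (Homo sapiens) for inhibition, read by MTT assay (on this read-out higher numbers stand for weaker inhibition and lower numbers for stronger inhibition), compound 1 `CN(C)C(=O)c1cc2cnc(NC3CCCCC3)nc2n1C1CCCC1` reads 25000 nM and compound 3 `O=C(Nc1ccccc1)c1cc2cnc(Nc3ccc(N4CCNCC4)cn3)nc2n1Cc1ccccc1` reads 3600 nM in this small set. Compound 2 `O=C(Nc1ccc[n+]([O-])c1)c1cc2cnc(Nc3ccc(N4CCNCC4)cn3)nc2n1C1CCCC1` reads 125000 nM and stands highest of the three, making it the weakest inhibitor here, with its gaps to both others beyond the scatter. Compound 4 `Cc1ccccc1NC(=O)c1cc2cnc(Nc3ccc(N4CCNCC4)cn3)nc2n1C1CCCC1` has not yet been measured. Among the measured compounds shown here, its only change from compound 2 is a group of 7 heavy atoms (7 carbon; one six-membered aromatic ring of carbon only) in place of a group of 7 heavy atoms (5 carbon, 1 nitrogen, 1 oxygen; one six-membered aromatic ring with 1 hetero atom), on an amide-type nitrogen and the rest of the structure stays the same. For the measured compounds named here, no measured pair isolates this change, so the expected size of the step rests on indirect evidence. Compound 3 also has a six-membered aromatic ring of carbon only on the amide-type nitrogen, though it differs from compound 2 elsewhere too, and for comparison compound 3 reads 3600 nM. The expected change in this assay is toward stronger inhibition and beyond the scatter, estimated as a 14-fold lower number from compound 2 to compound 4 (1.14 log units; beyond the scatter) on this evidence. For compound 4 the estimated value is 9000 nM with an expected range of 2500 nM to 35000 nM in this assay when measured.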

Compound 4, half-maximal inhibitory concentration: 2500 nM
The estimate for compound 4 lay 3.6-fold (0.56 log units) above the measured number; measured number inside the range.
By their numbers in this assay, from the lowest: compounds 4 and 3 (each within the scatter of the next); then compound 1; then compound 2.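

On the amide-type nitrogen, 2-methylphenyl in place of the ring with one hetero atom gives, in this assay, a 50-fold lower number from compound 2 to compound 4 (1.70 log units; beyond the scatter), with the rest of the structure unchanged. Among the compounds shown here, this is the first pair to isolate this position, and it shows that the group on the amide-type nitrogen can by itself move the read-out well beyond the scatter, even though the entering and leaving groups have the same heavy-atom count. Nothing measured here accounts for the size of this step.

Still open, as far as these compounds go, is whether the step follows from the loss of the ring nitrogen and its oxygen or from the gain of the methyl on the carbon-only ring. A pyridine ring without the oxygen on the amide-type nitrogen, with the rest of compound 4 held, would help separate the two.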